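Swapping a Pyridine for a Benzene on the Chain Carbon

The source may hold more compounds than are shown below. What is called first, only, known or untested is meant among the compounds shown, and "the series" means these compounds.

Measured so far:
compound 1, `N=C(NCCCc1c[nH]cn1)NCCC(c1ccc(Br)cc1)c1ccccn1` — 0.4
compound 2, `N=C(NCCCc1c[nH]cn1)NCCC(c1ccc(Cl)c(Cl)c1)c1ccccn1` — 0.8

Both compounds were tested in a functional assay on muscle tissue for agonist activity at histamine H2 receptor (Cavia porcellus); a higher number here means a larger maximal response, a lower number a smaller maximal response. Among the compounds with values here, compound 2 gives the higher of the two numbers, 0.8, and the single measured step, a number 0.40 higher from compound 1 to compound 2 (beyond the scatter), shows how much was gained by changing the halogen-bearing ring alone.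

Compound 3, `N=C(NCCCc1c[nH]cn1)NCCC(c1ccccc1)c1ccc(Cl)c(Cl)c1`, keeps the 3,4-dichlorophenyl group of compound 2 and changes the other ring on the same chain carbon: phenyl in place of pyridin-2-yl on a saturated chain carbon bound to an aromatic carbon and a saturated chain carbon. Within the data shown here, no measured step touches this ring, so the only comparison available concerns a different position and does not bear directly on the change. With no guidance from a matching step, the expectation for a number 0.20 lower from compound 2 to compound 3 (beyond the scatter) is a modest loss, kept close to the scatter. Compound 3 is therefore estimated at 0.6, with a range from 0.3 to 0.9.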

Compound 3, intrinsic activity: the largest response reached, as a fraction of the reference agonist's: 0.6
For compound 3 middle estimate and measured number coincide at the digits printed; the range from low to high includes it.
By their numbers in this assay, from the lowest: compound 1; then compound 3; then compound 2.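

The pyridin-2-yl ring had stayed fixed until now, and this comparison shows that it also influences the maximal response in this assay: the step is a number 0.20 lower from compound 2 to compound 3 (beyond the scatter). The change keeps a six-membered aromatic ring at this chain carbon and replaces only the ring nitrogen with carbon, yet that is enough to shift the result, while compound 3 still gives 0.6, so a clear response remains without the ring nitrogen. No measurement available here explains why this swap lowers the response.

As far as these compounds go, it remains open whether another ring on this chain carbon, such as pyridin-3-yl, thiazol-2-yl or cyclohexyl, would give a response closer to that of compound 2 or compound 3. From the compounds shown here alone, this ring swap has also been read only with 3,4-dichlorophenyl held in place, so its effect alongside 4-bromophenyl is unknown.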